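A few compounds are considered here, and "the series" means these few. Any claim that something is new, unique, unknown or untested is made for them only; others in the source may bear on it.

The series is built on a shared core carrying a thiosemicarbazide chain closed by a saturated ring on the thiocarbonyl carbon. In a functional assay on A-431 cells (Homo sapiens) for cytotoxicity, read by MTT assay, with a stated time of 72 h, tested at 100 uM (on this read-out lower numbers stand for less inhibition of growth and higher numbers for more inhibition of growth at the one concentration tested), compound 1 `Cc1ccnc(/C(N)=N/NC(=S)N2CCOCC2)c1` gives 82.8%. Compound 2 `Cc1ccnc(/C(N)=N/NC(=S)N2CCSCC2)c1`, which carries a thiomorpholin-4-yl ring instead, gives 79.6% in this assay, so that a number 3.2 percentage points lower from compound 1 to compound 2 (within the scatter). Compound 3 `N/C(=N\NC(=S)N1CCCCC1)c1ccccn1`, lacking the methyl on the core and carrying a piperidin-1-yl ring, gives 85.6% in this assay. Compound 3 thus has the highest of the three readings, but its gaps to compound 1 and to compound 2 both lie within the usual scatter, so the three compounds cannot be separated on these numbers.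

Compound 4 `Cc1ccnc(/C(N)=N/NC(=S)N2CCCCC2)c1` differs from compound 3 by methyl in place of hydrogen on an aromatic carbon. Within the data shown here, no measured step concerns a change at this position; the only step available, that from compound 1 to compound 2, concerns the ring on the thiocarbonyl carbon and stays within the scatter, and compound 1, which carries the same methyl as compound 4, sits close to compound 3. On this basis compound 4 is expected to show a step of a number 1.6 percentage points lower from compound 3 to compound 4 (within the scatter) in this assay, that is none beyond the scatter. The estimate for compound 4 in this assay is 84%, between 72% and 94%.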

Compound 4, percent growth inhibition at one concentration: 77.6%
Beside the measured number, compound 4's estimate is 6.4 percentage points above it, and the stated range covers the measured number.
By their numbers in this assay, from the lowest: compounds 4, 2, 1 and 3 (each within the scatter of the next).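

Among these compounds, compound 4 gives the first direct reading of methyl in place of hydrogen on an aromatic carbon, opposite the ring nitrogen: in this assay the change amounts to a number 8 percentage points lower from compound 3 to compound 4 (within the scatter), so with piperidin-1-yl held on the thiocarbonyl carbon, the methyl cannot be told apart from hydrogen at this position. With the methyl held on the core, the ring on the thiocarbonyl carbon can now be compared across three saturated rings: piperidin-1-yl in place of thiomorpholin-4-yl gives a number 2 percentage points lower from compound 2 to compound 4 (within the scatter), and piperidin-1-yl in place of morpholin-4-yl gives a number 5.2 percentage points lower from compound 1 to compound 4 (within the scatter), so none of these rings separates from the others. No supporting evidence bears on these readings.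

The compounds shown leave open whether a methoxy group, a chlorine atom or an amine at this position of the core would move the reading beyond the scatter. They also leave open whether an open-chain dimethylamino group in place of the saturated ring on the thiocarbonyl carbon would do so, and whether the four compounds would separate at other concentrations.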